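A few compounds are considered here, and "the series" means these few. Any claim that something is new, unique, unknown or untested is made for them only; others in the source may bear on it.

Compound 1 `CCCOc1cccc(-c2[nH]c3cc(OC)ccc3c(=O)c2C(=O)OCC)c1` was tested in an ADME assay on HEK293 cells (Homo sapiens) for cytotoxicity, read by luminescence, with a stated time of 72 h; on this read-out lower numbers stand for an effect already at smaller amounts and higher numbers for an effect only at larger amounts of compound. In this assay compound 1 gives > 22000 nM, which is a limit of the assay rather than a number. Compound 2 `CCCCOc1cccc(-c2[nH]c3cc(OC)ccc3c(=O)c2C(=O)OCC)c1` gives > 22000 nM in this assay, again only a limit. Compound 3 `CCOC(=O)c1c(-c2cccc([N+](=O)[O-])c2)[nH]c2cc(OC)ccc2c1=O` gives > 22000 nM in this assay, also a limit. The three comparisons between them are therefore a step that the two limits leave unreadable from compound 1 to compound 2, a step that the two limits leave unreadable from compound 1 to compound 3 and a step that the two limits leave unreadable from compound 2 to compound 3, and the limit of > 22000 nM in this assay, at which 3 of the 3 values shown sit, is all that the measured data offer.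

Compound 4 `CCOC(=O)c1c(-c2cccc(N(C)C)c2)[nH]c2cc(OC)ccc2c1=O` differs from compound 1 by dimethylamino in place of propoxy on an aromatic carbon. The closest measured parallel is the replacement on the same aromatic carbon in compound 3, whose > 22000 nM sits at the limit, so no direction or size can be read from the measured steps. Given (the limit of > 22000 nM in this assay, at which 3 of the 3 values shown sit), the step that the limit leaves unreadable from compound 1 to compound 4 is expected to stay within the scatter, most likely ending again at a limit. Compound 4 is estimated at 30000 nM in this assay, within a range from 12000 nM to 100000 nM.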

Compound 4, half-maximal effective concentration: > 22000 nM
Compound 4 was reported as a limit (the forecaster's own chance of this, stated with the estimate: 85%); the middle value is on the limit's open side.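

Compound 4 gives > 22000 nM in this assay, again only a limit. Its comparisons with compound 1, compound 2 and compound 3 therefore cannot be read: the limit of > 22000 nM in this assay, at which 4 of the 4 values shown sit. The compounds shown leave open at what concentration any of them would harm these cells, and whether swapping the group on the aromatic ring makes any difference.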